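The source may hold more compounds than are shown below. What is called first, only, known or untested is meant among the compounds shown, and "the series" means these compounds.

Measured so far:

Compound 1 `CCn1cc(-c2nc3ccccc3[nH]2)c(=O)c2cc(F)c(N3CCNCC3)cc21` – in this assay compound 1 gives > 10000 nM, which is a limit of the assay and not a number.
Compound 2 `CCn1cc(-c2nc3ccccc3[nH]2)c(=O)c2cc(F)c(N3CCNCC3)nc21` – compound 2 gives 3700 nM.
Compound 3 `CCn1cc(-c2nc3ccc(N)cc3[nH]2)c(=O)c2cc(F)c(N3CCNCC3)cc21` – compound 3 gives > 10000 nM, again a limit of the assay rather than a number.

All three were tested in a functional assay on Hep 3B2 cells (Homo sapiens) for cytotoxicity, read by sulforhodamine B assay, with a stated time of 48 h; on this read-out lower numbers stand for stronger inhibition of growth and higher numbers for weaker inhibition of growth. Compound 2 is the only one of the three to give an actual number; the other two values sit at a limit. The difference between the core of compound 1 and the core of compound 2 is not broken down here, so nothing can be said about the size of that step beyond what the two values show.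

From compound 1 to compound 3 the change is amino in place of hydrogen on an aromatic carbon. The step that the two limits leave unreadable from compound 1 to compound 3 cannot be read because the limit of > 10000 nM in this assay, at which 2 of the 3 values shown sit, hides both ends of it.

The compound still to be measured is compound 4 `CCn1cc(-c2nc3ccc(N)cc3[nH]2)c(=O)c2cc(F)c(N3CCNCC3)nc21`. It stands to compound 2 exactly as compound 3 stands to compound 1: the change is amino in place of hydrogen on an aromatic carbon, the same change, made on the core of compound 2 instead of the core of compound 1. The measured instance of this change is unreadable. The expectation can only rest on the value of compound 2, 3700 nM, taken as a starting point with no clear direction. The step from compound 2 to compound 4 is therefore estimated as a 1.1-fold higher number from compound 2 to compound 4 (0.03 log units; within the scatter). Compound 4 is expected to give about 4000 nM, with a likely range from 1000 nM to 15000 nM.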

Compound 4, concentration for 50% growth inhibition: > 10000 nM
Compound 4: no number, only a limit; the forecaster's own chance of this, stated with the estimate: 30%; at least 2.5-fold (0.39 log units) between middle value and limit.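

On the core of compound 2, amino in place of hydrogen on an aromatic carbon gives an at least 2.7-fold higher number from compound 2 to compound 4 (0.43 log units; beyond the scatter) in this assay, so on this core the change goes with weaker inhibition of growth. Compound 4 gives > 10000 nM, which is a limit of the assay and not a number. This shows the direction of the change on one core only: the same change from compound 1 to compound 3 cannot be read, so the data do not show whether the change carries from one core to the other, and the two steps cannot be compared, for the reason that follows: the limit of > 10000 nM in this assay, at which 3 of the 4 values shown sit.

The compounds shown leave open whether a hydroxyl, a methoxy or a carboxylic acid in place of the amino on that aromatic carbon would give a number rather than a limit on the core of compound 2. Any such group would have to be read against compound 2, which gives 3700 nM and is the only compound here with a value that is a number.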